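This account rests on a few compounds, and the source may have more. Where it says the series, first, only, none or still open, it means among the compounds named here.

Two compounds of this series have been characterised in a functional assay on CHO cells for positive allosteric modulation of metabotropic glutamate receptor 2 (Homo sapiens), read by scintillation counting and GTPgammaS binding, with a stated time of 30 min; on this read-out higher numbers stand for an effect only at larger amounts of compound and lower numbers for an effect already at smaller amounts. Compound 1 `CC(C)CCn1ccc(-c2ccccc2)c(C#N)c1=O` gives 8510 nM in this assay. Compound 2 `Cc1cc(Oc2ccc(-c3ccn(CC4CCC4)c(=O)c3C#N)cc2)ccn1` gives 126 nM in this assay. For the measured compounds named here, compound 2 therefore holds the lowest of the two numbers; its only neighbour, compound 1, sits at a far higher number, and that gap lies well beyond the scatter of repeated measurements. Going by the values given here, compounds 1 and 2 differ in several places at once, so their two values show only the overall gap between them, and no single-point step between measured compounds is available.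

Compound 3 `Cc1cc(Oc2ccc(-c3ccn(CC4CC4)c(=O)c3C#N)cc2)ccn1` is the next compound to be examined. It differs from compound 2 by cyclopropyl in place of cyclobutyl on a saturated chain carbon bound to an aromatic nitrogen. Among the compounds with values here, nothing among the measured compounds isolates the effect of such a change, so the step from compound 2 to compound 3 is expected to be small, a 1.2-fold higher number from compound 2 to compound 3 (0.08 log units; within the scatter), and not beyond the scatter in either direction. On this basis compound 3 is estimated at 150 nM in this assay, with a plausible range from 50 nM to 450 nM.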

Compound 3, half-maximal effective concentration: 832 nM
Beside the measured number, compound 3's estimate is 5.5-fold (0.74 log units) below it; the whole stated range lies below it.
By their numbers in this assay, from the lowest: compound 2; then compound 3; then compound 1.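

For the compounds shown here, the step is the first single-point reading: in this assay there is a 6.6-fold higher number from compound 2 to compound 3 (0.82 log units; beyond the scatter), with cyclopropyl in place of cyclobutyl on a saturated chain carbon bound to an aromatic nitrogen. It shows that this place is not indifferent to a small change, since exchanging a four-membered carbon ring for a three-membered one, a difference of a single heavy atom with no hydrogen-bond donor or acceptor on either group, moves the number beyond the scatter, and here the larger ring goes with the lower number. The compounds shown offer no measurement that would explain this difference.

On these data alone, whether the trend continues with a still larger ring remains open, since one reading cannot tell whether cyclopentyl at the same place, or an open chain such as a longer alkyl or methoxyethyl, would give a lower or a higher number. As far as these compounds go, it is also open whether a step of this size would recur if the group carried by the rest of the core were a different one, for instance if the methylpyridyl ether part of compound 2 gave way to a plain phenyl.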